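This account rests on a few compounds, and the source may have more. Where it says the series, first, only, none or still open, it means among the compounds named here.

Measured compounds:
Compound 1 `O=C(O)Cc1sc(C(c2ccc(F)cc2)c2ccc(F)cc2)nc1-c1cc(F)cc(F)c1` gives 35 nM in an in vitro assay on HEK385-7 cells for displacement of a labelled ligand from prostaglandin D2 receptor 2 (Homo sapiens); a higher number here means a weaker inhibitor, a lower number a stronger inhibitor.
Compound 2 `NS(=O)(=O)c1cccc(-c2nc(C(c3ccc(F)cc3)c3ccc(F)cc3)sc2CC(=O)O)c1` gives 140 nM.
Compound 3 `O=C(O)Cc1sc(C(c2ccc(F)cc2)c2ccc(F)cc2)nc1-c1ccncc1` gives 5.3 nM.

Among these three, compound 3 gives the lowest number in this assay. Its nearest neighbour is compound 1, and a 6.6-fold lower number from compound 1 to compound 3 (0.82 log units; beyond the scatter) sets the two apart beyond the scatter. Compound 2 lies furthest away, with a 26-fold lower number from compound 2 to compound 3 (1.42 log units; beyond the scatter). The third measured step, a 4.0-fold higher number from compound 1 to compound 2 (0.60 log units; beyond the scatter), exchanges a group on the same aromatic carbon.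

The next compound, compound 4 `Cc1cc(-c2nc(C(c3ccc(F)cc3)c3ccc(F)cc3)sc2CC(=O)O)ccn1`, differs from compound 3 by methyl in place of hydrogen on an aromatic carbon. Going by the values given here, none of the measured steps bears directly on this change: each of them swaps the whole aryl group on that carbon for another, and those swaps were modest to large. Among the compounds with values here, a methyl added to a kept pyridin-4-yl has no precedent among the measured compounds, so there is no close guide. Because the shared core and the pyridin-4-yl of compound 3 with its 5.3 nM are retained, compound 4 is expected to stay close to compound 3, with a step no larger than the scatter in either direction. The estimate for compound 4 in this assay is therefore 6 nM, with a range from 2 nM to 20 nM. This corresponds to an expected 1.1-fold higher number from compound 3 to compound 4 (0.05 log units; within the scatter).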

Compound 4, half-maximal inhibitory concentration: 3.1 nM
The estimate for compound 4 lay 1.9-fold (0.29 log units) above the measured number, and the stated range covers the measured number.
By their numbers in this assay, from the lowest: compounds 4 and 3 (each within the scatter of the next); then compound 1; then compound 2.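

In this assay, the methyl on an aromatic carbon next to the ring nitrogen gives a 1.7-fold lower number from compound 3 to compound 4 (0.23 log units; within the scatter), so this carbon of the pyridin-4-yl carries a methyl without a step that can be told from the scatter, something the earlier whole-aryl swaps could not show. The separation from the other aryl groups also survives the added methyl: 2-methylpyridin-4-yl in place of 3,5-difluorophenyl gives an 11-fold lower number from compound 1 to compound 4 (1.05 log units; beyond the scatter), and in place of 3-sulfamoylphenyl it gives a 45-fold lower number from compound 2 to compound 4 (1.65 log units; beyond the scatter), both large steps, so the pair of pyridine compounds stands apart from compound 1 and compound 2. No measurement is available that accounts for this outcome at the level of the compounds themselves.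

Going by these compounds, whether the same carbon accepts anything beyond methyl, such as an ethyl, a methoxy or an amine, remains open, and so does the outcome of a methyl placed elsewhere on this ring. The compounds shown also leave open whether a chloro or a second methyl on the pyridine would keep the number in the same range.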